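The source may hold more compounds than are shown below. What is called first, only, known or untested is meant among the compounds shown, and "the series" means these compounds.

Of the compounds shown here, three with a shared core have been measured so far in an ADME assay for permeability, using PAMPA, at pH 7.4; a lower number here means that the compound crosses the layer more slowly, a higher number that the compound crosses the layer faster. Compound 1 `Cc1cc(NC(=O)Nc2ccc(Cl)c(Cl)c2)c2ccccc2n1` gives 197 10^-6 cm/s, compound 2 `CC(=O)c1ccc(NC(=O)Nc2cc(C)nc3ccccc23)cc1` gives 473 10^-6 cm/s, and compound 3 `Cc1cc(NC(=O)Nc2ccc(SC(F)(F)F)cc2)c2ccccc2n1` gives 206 10^-6 cm/s. Compound 3 therefore sits level with compound 1, within the usual scatter of repeated measurements, and clearly under compound 2.

The next compound, compound 4 `Cc1cc(NC(=O)Nc2ccc(Cl)cc2)c2ccccc2n1`, differs from compound 3 in one place, with chloro in place of (trifluoromethyl)sulfanyl on an aromatic carbon.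

Among the measured compounds shown here, only one measured step involves the group that leaves. That is a 2.3-fold lower number from compound 2 to compound 3 (0.36 log units; beyond the scatter), a modest step with acetyl as the other group, so it says little directly about chloro. A closer guide is compound 1, which carries chloro and a further chloro group, and which gives 197 10^-6 cm/s. For the measured compounds named here, this value is level with the one for compound 3, so swapping (trifluoromethyl)sulfanyl for chloro need not move the number much. Going by the values given here, no measurement yet shows chloro alone on this ring.

The expected change is therefore a 1.1-fold higher number from compound 3 to compound 4 (0.05 log units; within the scatter), which amounts to no step beyond the scatter. For compound 4 the estimated value is 230 10^-6 cm/s, with an expected range from 120 10^-6 cm/s to 440 10^-6 cm/s.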

Compound 4, apparent permeability: 537 10^-6 cm/s
For compound 4 the middle estimate is 2.3-fold (0.37 log units) below the measured one; the measured number lies above the stated range.
By their numbers in this assay, from the lowest: compounds 1 and 3 (each within the scatter of the next); then compounds 2 and 4 (each within the scatter of the next).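

In this assay, the group on the aromatic carbon para to a large group clearly matters: chloro in place of (trifluoromethyl)sulfanyl gives a 2.6-fold higher number from compound 3 to compound 4 (0.42 log units; beyond the scatter), a step beyond the scatter from a change at this single place. A second chloro on the same ring matters too, since hydrogen in place of that chloro gives a 2.7-fold higher number from compound 1 to compound 4 (0.44 log units; beyond the scatter), so a single chloro and a pair of chloro groups cannot be treated as interchangeable here. Chloro in place of acetyl gives only a 1.1-fold higher number from compound 2 to compound 4 (0.06 log units; within the scatter), a step within the scatter, so these two quite different groups cannot be told apart in this assay, although each stands clearly apart from (trifluoromethyl)sulfanyl.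

Going by these compounds, whether an amine, a carboxylic acid or a longer chain at this position would read like compound 3 or like compounds 2 and 4 remains open, as does the number that a bare hydrogen there would give. No measured evidence is at hand to explain any of these steps.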